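Propyl in place of phenyl on the aromatic carbon

The source may hold more compounds than are shown below. What is called first, only, known or untested is meant among the compounds shown, and "the series" means these compounds.

Compound 1 `COc1ccccc1N1CCN(CCCNc2ncccc2C(=O)N(C)C)CC1` gives 20 nM in a functional assay on aorta for antagonist activity at Alpha-1D adrenergic receptor (Rattus norvegicus); on this read-out higher numbers stand for weaker binding and lower numbers for tighter binding; compound 2 `CN(C)C(=O)c1cccnc1NCCCN1CCN(c2ccccc2C#N)CC1` gives 10 nM, and compound 3 `CN(C)C(=O)c1cccnc1NCCCN1CCN(c2ccccc2-c2ccccc2)CC1` gives 63.1 nM. Compound 3 carries the highest number of the three: a 3.2-fold higher number from compound 1 to compound 3 (0.50 log units; beyond the scatter) and a 6.3-fold higher number from compound 2 to compound 3 (0.80 log units; beyond the scatter), while a 2.0-fold lower number from compound 1 to compound 2 (0.30 log units; within the scatter). Compound 4 `CCCc1ccccc1N1CCN(CCCNc2ncccc2C(=O)N(C)C)CC1` differs from compound 3 by propyl in place of phenyl on an aromatic carbon. Going by the values given here, no measured step swaps phenyl for a chain; the two steps that end at compound 3 show that phenyl in place of the smaller methoxy or cyano group raises the number. For compound 4 a downward step of similar modest size is therefore expected, a 2.5-fold lower number from compound 3 to compound 4 (0.40 log units; beyond the scatter). The estimate for compound 4 in this assay is 25 nM, with a range from 8 nM to 80 nM.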

Compound 4, dissociation constant: 31.6 nM
Beside the measured number, compound 4's estimate is 1.3-fold (0.10 log units) below it; the range from low to high includes it.
By their numbers in this assay, from the lowest: compounds 2, 1, 4 and 3 (each within the scatter of the next, the first and the last beyond it).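

In this assay, propyl on this aromatic carbon cannot be told apart from phenyl, with a 2.0-fold lower number from compound 3 to compound 4 (0.30 log units; within the scatter), or from methoxy, with a 1.6-fold higher number from compound 1 to compound 4 (0.20 log units; within the scatter). Only cyano separates from propyl, with a 3.2-fold higher number from compound 2 to compound 4 (0.50 log units; beyond the scatter), so this position accepts a group with no ring and no hydrogen-bond acceptors without leaving the range of the methoxy compound. Nothing available explains these steps.

Still open, from the compounds shown here alone, is how a longer chain such as butyl, or an amine, would read at this carbon. Going by these compounds, whether propyl gives the same result on another core also remains open.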